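A few compounds are considered here, and "the series" means these few. Any claim that something is new, unique, unknown or untested is made for them only; others in the source may bear on it.

Working notes on the series.

Compound 1 `O=C1[C@@H](NS(=O)(=O)c2ccc(-c3ccon3)s2)CCN1Cc1cc2cc[nH]cc-2n1` gives 49% in an assay on isolated protein for inhibition of coagulation factor X (Oryctolagus cuniculus), tested at 1 uM; a higher number here means more inhibition at the concentration tested (going by the name of the read-out), a lower number less inhibition. Compound 2 `O=C1[C@@H](NS(=O)(=O)c2cc3ccnc(Cl)c3s2)CCN1Cc1cc2[nH]cccc-2n1` shares the core of compound 3; in this assay compound 2 gives 45%; these two numbers from compound 1 and compound 2 lie within the usual scatter of each other. Compound 3 `CC(C)(C)c1ccc(S(=O)(=O)N[C@H]2CCN(Cc3cc4[nH]cccc-4n3)C2=O)cc1` gives 22% and stands lowest of the three measured numbers: compound 2 is the nearest, and compound 1 the furthest, both beyond the scatter.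

Compound 4 `O=C1[C@@H](NS(=O)(=O)c2ccc(-c3ccon3)s2)CCN1Cc1cc2[nH]cccc-2n1` has not yet been measured. It differs from compound 3 in one place: 5-(1,2-oxazol-3-yl)thiophen-2-yl in place of 4-(tert-butyl)phenyl on a sulfonyl sulfur. Among the compounds with values here, the step that bears on this is the one from compound 2 to compound 3, a number 23 percentage points lower from compound 2 to compound 3 (beyond the scatter), where the same 4-(tert-butyl)phenyl group entered on the sulfonyl sulfur in place of a two-ring heteroaromatic group and the inhibition fell. Compound 1 carries the same 5-(1,2-oxazol-3-yl)thiophen-2-yl group as compound 4 on a different core and gives the highest number seen.

Compound 4 is therefore expected to move back up, with an estimated step of a number 23 percentage points higher from compound 3 to compound 4 (beyond the scatter). The estimate for compound 4 is 45%, with a range from 30% to 60%.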

Compound 4, a percentage reported as inhibition, at one concentration (the size of the read-out at that concentration, not a potency): 31%
The estimate for compound 4 lay 14 percentage points above the measured number; low and high end bracket the measured number.
By their numbers in this assay, from the lowest: compounds 3 and 4 (each within the scatter of the next); then compounds 2 and 1 (each within the scatter of the next).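

On the core of compound 3, the step of a number 9 percentage points higher from compound 3 to compound 4 (within the scatter) in this assay does not separate 5-(1,2-oxazol-3-yl)thiophen-2-yl from 4-(tert-butyl)phenyl on the sulfonyl sulfur, even though the entering group has 3 hydrogen-bond acceptors and the leaving group has 0. The two-ring group of compound 2 now stands apart from both single-substituent groups on this core, since the step of a number 14 percentage points lower from compound 2 to compound 4 (beyond the scatter) lies beyond the scatter, as does the earlier step of a number 23 percentage points lower from compound 2 to compound 3 (beyond the scatter) on the same core. With the 5-(1,2-oxazol-3-yl)thiophen-2-yl group held fixed, the step of a number 18 percentage points lower from compound 1 to compound 4 (beyond the scatter) shows that the group on the saturated chain carbon bound to an amide-type nitrogen in a ring also moves the number, so the sulfonyl group alone does not set the level of compound 1.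

Nothing at hand gives a reason for any of these differences. Still open, going by these compounds, is whether the two-ring group of compound 2 would hold or raise its number on the core of compound 1, and whether an amine or a carboxylic acid in place of the 1,2-oxazol-3-yl ring on the thiophene would shift the number.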